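The source may report more compounds than this note shows. Statements on the series, on what has been measured and on what is new or still open speak of the compounds shown alone.

Measured compounds:
compound 1 `Clc1cccc(N2CCN(CCCCNc3nc(NCc4ccco4)c4ccccc4n3)CC2)c1Cl`: 3870 nM
compound 2 `Cc1cccc(N2CCN(CCCCNc3nc(NCc4ccco4)c4ccccc4n3)CC2)c1C`: 1070 nM

In a functional assay on DU-145 cells (Homo sapiens) for cytotoxicity, read by MTT assay, with a stated time of 2 days (on this read-out lower numbers stand for stronger inhibition and higher numbers for weaker inhibition), compound 1 gives the higher of the two numbers; its nearest neighbour is compound 2, reached by a 3.6-fold lower number from compound 1 to compound 2 (0.56 log units; beyond the scatter). Compound 3 `Fc1ccc2nc(NCCCCN3CCN(c4cccc(Cl)c4Cl)CC3)nc(NCc3ccco3)c2c1` keeps the whole of compound 1 and differs only by fluoro in place of hydrogen on an aromatic carbon. Within the data shown here, the one measured step changes the phenyl group on the ring nitrogen, so nothing measured bears on a change at the fused ring; the expected step is therefore a 1.1-fold lower number from compound 1 to compound 3 (0.04 log units; within the scatter), none beyond the scatter. Compound 3 is expected to give about 3500 nM in this assay, in the range 1500 nM to 8000 nM.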

Compound 3, half-maximal inhibitory concentration: 670 nM
Beside the measured number, compound 3's estimate is 5.2-fold (0.72 log units) above it; measured number below the stated range.
By their numbers in this assay, from the lowest: compounds 3 and 2 (each within the scatter of the next); then compound 1.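

In this assay, fluoro in place of hydrogen on an aromatic carbon of the fused system of two rings gives a 5.8-fold lower number from compound 1 to compound 3 (0.76 log units; beyond the scatter) in a step of modest size. This shows that the shared core, which the earlier pair left unchanged, also affects the number, and that a single fluorine atom is enough to do so. Nothing given here accounts for this step. On these data alone, whether chloro, methoxy or an amine on this same carbon would move the number likewise remains open. So does whether fluoro here would give a similar step on compound 2.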